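Azido for methyl on compound 3

The source may report more compounds than this note shows. Statements on the series, on what has been measured and on what is new or still open speak of the compounds shown alone.

Compound 1 `COc1cc(N(Cc2ccc(Cl)cc2)C(=O)CSC(=S)N2CCN(C(=O)OC(C)(C)C)CC2)cc(OC)c1OC`: 8490 nM
Compound 2 `COc1cc(N(Cc2ccc(C)cc2)C(=O)CSC(=S)N2CCN(C(=O)OC(C)(C)C)CC2)cc(OC)c1OC`: > 20000 nM (a limit)
Compound 3 `COc1ccc(CN(C(=O)CSC(=S)N2CCN(C(=O)OC(C)(C)C)CC2)c2cc(OC)c(OC)c(OC)c2)cc1C`: > 20000 nM (a limit)

These values come from a functional assay on HCT-116 cells (Homo sapiens) for inhibition, read by CCK-8 assay, with a stated time of 48 h; on this read-out lower numbers stand for stronger inhibition and higher numbers for weaker inhibition. In this series, compound 3 gives no number, only the limit > 20000 nM. That is the limit of > 20000 nM in this assay, at which 2 of the 3 values shown sit.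

Compound 4 `COc1ccc(CN(C(=O)CSC(=S)N2CCN(C(=O)OC(C)(C)C)CC2)c2cc(OC)c(OC)c(OC)c2)cc1N=[N+]=[N-]` carries azido in place of methyl on an aromatic carbon, ortho to a methoxy group: azido in place of methyl on an aromatic carbon.

Among the measured compounds shown here, no measured step involves azido, so the evidence is indirect. Methyl in place of chloro gave an at least 2.3-fold higher number from compound 1 to compound 2 (0.37 log units; beyond the scatter). 4-Methoxy-3-methylphenyl in place of 4-chlorophenyl gave an at least 2.3-fold higher number from compound 1 to compound 3 (0.37 log units; beyond the scatter). The remaining comparison gave a step that the two limits leave unreadable from compound 2 to compound 3. Both readable steps end at a limit, so they set only a minimum size.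

On the strength of these steps, a large move away from the limit is not expected. A modest drop towards the number of compound 1 remains possible, and compound 1 gives 8490 nM. The expected change is an at least 1.1-fold lower number from compound 3 to compound 4 (0.04 log units; that floor lies within the scatter). For compound 4 the estimated value is 18000 nM, with an expected range from 6000 nM to 40000 nM.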

Compound 4, half-maximal inhibitory concentration: 780 nM
Estimate against measurement, compound 4: 23-fold (1.36 log units) above; the whole stated range lies above it.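

In this assay, among the compounds shown here, the aromatic carbon ortho to a methoxy group proves far more sensitive than the earlier compounds could show: azido in place of methyl gives an at least 25-fold lower number from compound 3 to compound 4 (1.40 log units; beyond the scatter). For the compounds shown here, the 3-azido-4-methoxyphenyl group also goes well past the only earlier number, with an 11-fold lower number from compound 1 to compound 4 (1.04 log units; beyond the scatter), while the change from 4-methylphenyl gives an at least 25-fold lower number from compound 2 to compound 4 (1.40 log units; beyond the scatter). Compound 2 and compound 3 each give only a limit, so the steps starting from them set only a minimum size: the limit of > 20000 nM in this assay, at which 2 of the 4 values shown sit.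

The compounds shown leave open whether this response is specific to azido or would also appear with an amine, a nitrile or a chloro on this carbon. They also leave open whether azido would have the same effect without the neighbouring methoxy group.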